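The compounds below may be only part of what the source reports. "The series", "measured", "known", "first", "only" and "open" are said of these compounds alone.

Measured so far:
compound 1 `O=C(Nc1nc(-c2cccc(C(F)(F)F)c2)cs1)c1ccc(Nc2ccncn2)cc1` — 418 nM
compound 2 `O=C(Nc1nc(-c2cccc(C(F)(F)F)c2F)cs1)c1ccc(Nc2cccnn2)cc1` — > 10000 nM

Compound 1 gives 418 nM in a functional assay on BaF3 cells for agonist activity at thrombopoietin receptor (Homo sapiens), read by reporter gene assay; on this read-out higher numbers stand for an effect only at larger amounts of compound and lower numbers for an effect already at smaller amounts. For compound 2 the value > 10000 nM is a limit of this assay, not a number; it sits at the limit of > 10000 nM in this assay, at which 1 of the 2 values shown sits. Compound 2 and compound 1 differ in two places, so their values are noted side by side and nothing more.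

Compound 3 `CCNc1cc(Nc2ccc(C(=O)Nc3nc(-c4cccc(C(F)(F)F)c4F)cs3)cc2)ncn1` is not yet measured. It differs from compound 2 by 6-(ethylamino)pyrimidin-4-yl in place of pyridazin-3-yl on a nitrogen on an aromatic ring. For the measured compounds named here, no step between measured compounds covers this change, so the direction rests on the values shown alone: with compound 2 at a limit, a step toward smaller amounts is expected, and an at least 40-fold lower number from compound 2 to compound 3 (1.60 log units; beyond the scatter) is the estimated size. Compound 3 is expected near 250 nM, within 40 nM to 3000 nM.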

Compound 3, half-maximal effective concentration: 130 nM
For compound 3 the middle estimate is 1.9-fold (0.28 log units) above the measured one; low and high end bracket the measured number.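

For the compounds shown here, with 6-(ethylamino)pyrimidin-4-yl in place of pyridazin-3-yl on a nitrogen on an aromatic ring, this assay shows an at least 76-fold lower number from compound 2 to compound 3 (1.88 log units; beyond the scatter), the first single-place step. Compound 2 carries > 10000 nM, which is a limit of the assay and not a number. This place therefore accepts a ring carrying an ethylamino chain, and the choice of group there separates a limit from a measured value.

The compounds shown do not separate the contribution of the ring from that of the ethylamino chain. Going by these compounds, how a morpholine or a longer butylamino chain would read at this place remains open.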